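The source may hold more compounds than are shown below. What is called first, only, known or untested is meant among the compounds shown, and "the series" means these compounds.

Values in an ADME assay on J774 cells (Mus musculus) for cytotoxicity, read by resazurin assay, with a stated time of 72 h; a higher number here means that more compound is tolerated, a lower number that less compound is tolerated:
- compound 1 `C/C(=N\Nc1nc(-c2ccncc2)cs1)c1ccc(Cl)c(Cl)c1`: 39800 nM
- compound 2 `C/C(=N\Nc1nc(-c2ccc(Br)cc2)cs1)c1ccc(Cl)c(Cl)c1`: > 50000 nM
- compound 3 `COc1ccc(-c2csc(N/N=C(\C)c3ccc(Cl)c(Cl)c3)n2)cc1`: not yet measured

Compound 2 gives only a limit of the assay, > 50000 nM. Compound 3 differs from it by methoxy in place of bromo on an aromatic carbon, which turns 4-bromophenyl into 4-methoxyphenyl. Among the measured compounds shown here, one measured step bears on this change: an at least 1.2-fold higher number from compound 1 to compound 2 (0.09 log units; that floor lies within the scatter), which put 4-bromophenyl in place of pyridin-4-yl. For the measured compounds named here, with only that small step to go on, no change beyond the scatter is expected in this assay. The expected step is an at least 1.1-fold lower number from compound 2 to compound 3 (0.04 log units; that floor lies within the scatter). For compound 3 the estimated value is 45000 nM, with an expected range from 20000 nM to 100000 nM.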

Compound 3, half-maximal cytotoxic concentration: > 50000 nM
Compound 3: a limit, no number; the forecaster's own chance of this, stated with the estimate: 55%; middle value at least 1.1-fold (0.04 log units) from the limit.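

With methoxy in place of bromo, compound 3 in this assay gives > 50000 nM, which is again a limit and not a number. Put in place of pyridin-4-yl, 4-methoxyphenyl gives an at least 1.2-fold higher number from compound 1 to compound 3 (0.09 log units; that floor lies within the scatter). The change from bromo to methoxy cannot be read as a step, because compound 2 and compound 3 both rest on the same limit: the limit of > 50000 nM in this assay, at which 2 of the 3 values shown sit.

From the compounds shown here alone, how far the true values of compound 2 and compound 3 lie from that limit stays open. So does whether an amine or a carboxylic acid on this aromatic carbon would give a measurable number in this assay.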